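Aryl bromine shift on the benzoyl group of compound 3

This account rests on a few compounds, and the source may have more. Where it says the series, first, only, none or still open, it means among the compounds named here.

In a functional assay on Ehrlich cells (Mus musculus) for cytotoxicity, read by trypan blue exclusion, with a stated time of 48 h (a higher number here means a weaker inhibitor, a lower number a stronger inhibitor), compound 1 `COc1ccc(C(=O)c2cc(C)ccc2OCC(=O)NNC(=O)c2cc3ccccc3oc2=O)cc1` gives 41200 nM. Compound 2 `Cc1ccc(OCC(=O)NNC(=O)c2cc3ccccc3oc2=O)c(C(=O)c2ccccc2Cl)c1` gives 48400 nM in this assay, and compound 3 `Cc1ccc(OCC(=O)NNC(=O)c2cc3ccccc3oc2=O)c(C(=O)c2cccc(Br)c2)c1` gives 68500 nM in this assay. The three numbers lie within the usual scatter of one another: the steps are a 1.2-fold higher number from compound 1 to compound 2 (0.07 log units; within the scatter), a 1.7-fold higher number from compound 1 to compound 3 (0.22 log units; within the scatter) and a 1.4-fold higher number from compound 2 to compound 3 (0.15 log units; within the scatter). Compound 3 therefore cannot be set apart from compound 1 or compound 2 on these numbers.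

Compound 4 `Cc1ccc(OCC(=O)NNC(=O)c2cc3ccccc3oc2=O)c(C(=O)c2ccc(Br)cc2)c1` differs from compound 3 only in this: 4-bromophenyl in place of 3-bromophenyl on a carbonyl carbon. Within the data shown here, none of the measured steps moves a bromine within the same aryl ring; the three steps exchange whole aryl groups on the carbonyl carbon, and each of them stays within the scatter. The change to compound 4 is smaller in kind than any of those, so no step beyond the scatter is expected in this assay for compound 4, in either direction: the expected step is a 1.1-fold lower number from compound 3 to compound 4 (0.02 log units; within the scatter). The estimate for compound 4 in this assay is 65000 nM, with a range from 33000 nM to 130000 nM.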

Compound 4, half-maximal inhibitory concentration: 91100 nM
Compound 4: middle estimate off by 1.4-fold (0.15 log units), on the low side; measured number inside the range.
By their numbers in this assay, from the lowest: compounds 1, 2, 3 and 4 (each within the scatter of the next, the first and the last beyond it).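

In this assay, the exchange of 3-bromophenyl for 4-bromophenyl on the carbonyl carbon, the first comparison within a single bromophenyl pair, stays within the scatter (a 1.3-fold higher number from compound 3 to compound 4 (0.12 log units; within the scatter)), as does the exchange of 2-chlorophenyl for 4-bromophenyl (a 1.9-fold higher number from compound 2 to compound 4 (0.27 log units; within the scatter)). Bromo in place of methoxy on an aromatic carbon gives the only step among these four compounds that lies beyond the scatter, and only modestly (a 2.2-fold higher number from compound 1 to compound 4 (0.34 log units; beyond the scatter)), so at this one position the methoxy compound is a slightly stronger inhibitor than the bromo compound. Nothing available explains this step.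

As far as these compounds go, whether an amine or a carboxylic acid in place of the bromine on the 4-bromophenyl group would give a larger step remains open. All four compounds also leave open how far any aryl group on this carbonyl carbon can shift the number.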